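The compounds below may be only part of what the source reports. "The series", "measured", "known", "first", "only" and "open" are said of these compounds alone.

Within the data shown here, in an ADME assay on the whole organism (Mus musculus, strain Swiss Webster) for pharmacokinetics, read by LC-MS, at a dose of 50 mg/kg by the oral route (on this read-out lower numbers stand for lower exposure and higher numbers for higher exposure at the dose given), compound 2 `O=C(Nc1ccc(F)c(-c2nc3ncc(-c4ccc(O)cc4)cc3[nH]2)c1)N1CCCC1` gives 137 ng.h/mL and is the lower of the two numbers so far. Among the measured compounds shown here, the only comparison is compound 1 `O=C(Nc1ccc(F)c(-c2nc3ncc(C(F)(F)F)cc3[nH]2)c1)N1CCCC1`, which gives 489 ng.h/mL on the same measure.

Compound 3 `O=C(Nc1ccc(F)c(-c2nc3ncc(-c4ccccc4F)cc3[nH]2)c1)N1CCCC1`, not yet measured, shares the core of compound 2 and differs in one group, 2-fluorophenyl in place of 4-hydroxyphenyl on an aromatic carbon with 2-fluorophenyl in place of 4-hydroxyphenyl on an aromatic carbon.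

For the measured compounds named here, only one measured step bears on this change. Putting 4-hydroxyphenyl in place of trifluoromethyl at that same carbon gave a 3.6-fold lower number from compound 1 to compound 2 (0.55 log units; beyond the scatter) and counts as a modest step. Compound 3 gives up the 4-hydroxyphenyl group but does not regain trifluoromethyl, so at most a partial return towards compound 1 seems reasonable. Going by the values given here, no compound with 2-fluorophenyl has been measured, and a single step is thin evidence, so the direction is tentative.

The expected change is a 2.2-fold higher number from compound 2 to compound 3 (0.34 log units; beyond the scatter) in this rough estimate, a modest rise. For compound 3 the estimated value is 300 ng.h/mL with an expected range of 110 ng.h/mL to 800 ng.h/mL around it.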

Compound 3, area under the concentration-time curve: 4870 ng.h/mL
Estimate against measurement, compound 3: 16-fold (1.21 log units) below; measured number outside the range, above it.
By their numbers in this assay, from the lowest: compound 2; then compound 1; then compound 3.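

In this assay, this carbon, two atoms from the ring nitrogen, proves far more sensitive than the first step suggested: 2-fluorophenyl in place of 4-hydroxyphenyl gives a 36-fold higher number from compound 2 to compound 3 (1.55 log units; beyond the scatter), a large step between two groups of equal heavy-atom count. An aromatic ring here does not by itself mean a lower number, for 2-fluorophenyl in place of trifluoromethyl gives a 10-fold higher number from compound 1 to compound 3 (1.00 log units; beyond the scatter), so one phenyl group lies below trifluoromethyl and the other above it. Nothing available here accounts for this jump in exposure.

The step from compound 2 to compound 3 removes a hydroxyl group and adds a fluorine at a different place on the phenyl ring, so these compounds cannot show which of those changes carries the rise. Unsubstituted phenyl or a phenyl ring bearing a methoxy group at this carbon would help separate them, and the area under the curve alone leaves open whether the higher number reflects more drug entering the body or drug leaving it more slowly.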